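Adding a hydroxy group to compound 1

The source may hold more compounds than are shown below. What is called first, only, known or untested is meant among the compounds shown, and "the series" means these compounds.

- compound 1 `COc1ccc(CN(C(=O)CSC(=S)N2CCN(C(C)=O)CC2)c2cc(OC)c(OC)c(OC)c2)cc1`: 370 nM
- compound 2 `COc1ccc(CN(C(=O)CSC(=S)N2CCc3ccccc3C2)c2cc(OC)c(OC)c(OC)c2)cc1`: > 20000 nM

Among the compounds with values here, in a functional assay on KYSE-450 cells (Homo sapiens) for inhibition, read by CCK-8 assay, with a stated time of 48 h (on this read-out lower numbers stand for stronger inhibition and higher numbers for weaker inhibition), compound 1 gives 370 nM, the only exact number so far. The entry for compound 2, > 20000 nM, is a limit of the assay.

Compound 3 `COc1ccc(CN(C(=O)CSC(=S)N2CCN(C(C)=O)CC2)c2cc(OC)c(OC)c(OC)c2)cc1O` keeps the 4-acetylpiperazin-1-yl group of compound 1 and changes the other end of the molecule: hydroxy in place of hydrogen on an aromatic carbon, turning 4-methoxybenzyl into 3-hydroxy-4-methoxybenzyl.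

Within the data shown here, the only measured step, an at least 54-fold higher number from compound 1 to compound 2 (1.73 log units; beyond the scatter), is large, but it swaps the group on the thiocarbonyl carbon and leaves 4-methoxybenzyl untouched. Among the measured compounds shown here, that step therefore sets neither a size nor a direction for the new change, and no measured step covers this spot. The expectation stays close to compound 1 at 370 nM.

The expected change is a 1.5-fold lower number from compound 1 to compound 3 (0.17 log units; within the scatter), which would lie within the scatter of this assay. For compound 3 the estimated value is 250 nM, with an expected range of 50 nM to 1000 nM.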

Compound 3, half-maximal inhibitory concentration: 210 nM
Beside the measured number, compound 3's estimate is 1.2-fold (0.08 log units) above it; low and high end bracket the measured number.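

Putting hydroxy in place of hydrogen on this aromatic carbon gives a 1.8-fold lower number from compound 1 to compound 3 (0.25 log units; within the scatter) in this assay, so the two compounds cannot be told apart on this read-out. Within the data shown here, this is the first view of the 4-methoxybenzyl end of the molecule, since the earlier step changed only the group on the thiocarbonyl carbon, and it shows that this spot, ortho to a methoxy group, can carry a hydroxy group without a change beyond the scatter. The compounds shown offer no measurement that would explain this outcome.

Still open, going by these compounds, is whether other groups at the same spot would be accepted as well, such as an amino group, a fluorine atom or a longer ethoxy chain. On these data alone, it is also open whether the hydroxy group would behave the same way on the 3-hydroxy-4-methoxybenzyl end if the acetyl group on the piperazine were replaced by a carboxylic acid.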